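This account rests on a few compounds, and the source may have more. Where it says the series, first, only, none or still open, it means among the compounds named here.

Compound 2 `CN1[C@@H]2c3[nH]c4ccccc4c3C[C@H]1[C@H](C#N)N1[C@@H](CNC(=O)c3cccc4c3CCCC4)c3[nH]c4ccccc4c3C[C@@H]21` carries the 1,2,3,4-tetrahydronaphthalen-5-yl group on the carbonyl carbon, and in a functional assay on HT-29 cells (Homo sapiens) for cytotoxicity, read by MTT assay, with a stated time of 72 h (a lower number here means a stronger inhibitor, a higher number a weaker inhibitor), compound 2 gives 3340 nM, the highest of the three numbers shown. Compound 1 `CN1[C@@H]2c3[nH]c4ccccc4c3C[C@H]1[C@H](C#N)N1[C@@H](CNC(=O)c3ccc(F)cc3)c3[nH]c4ccccc4c3C[C@@H]21` gives 1370 nM in this assay, and compound 3 `CN1[C@@H]2c3[nH]c4ccccc4c3C[C@H]1[C@H](C#N)N1[C@@H](CNC(=O)c3ccc4ccccc4n3)c3[nH]c4ccccc4c3C[C@@H]21` gives 150 nM. Compound 4 `CN1[C@@H]2c3[nH]c4ccccc4c3C[C@H]1[C@H](C#N)N1[C@@H](CNC(=O)c3cc4ccccc4[nH]3)c3[nH]c4ccccc4c3C[C@@H]21` differs from compound 2 in one place: 1H-indol-2-yl in place of 1,2,3,4-tetrahydronaphthalen-5-yl on a carbonyl carbon. Among the compounds with values here, two measured steps bear on this change. a 22-fold lower number from compound 2 to compound 3 (1.35 log units; beyond the scatter) shows a large drop when quinolin-2-yl, another bicyclic aromatic group with one hetero atom, took this position, and a 9.1-fold lower number from compound 1 to compound 3 (0.96 log units; beyond the scatter) points the same way, whereas a 2.4-fold higher number from compound 1 to compound 2 (0.39 log units; beyond the scatter) was modest. Within the data shown here, a sizeable fall in this assay is therefore expected for compound 4, although no measured compound tests the hydrogen-bond donor it brings. Compound 4 is estimated at 300 nM, with a range from 80 nM to 1200 nM. That estimate means an expected step of an 11-fold lower number from compound 2 to compound 4 (1.05 log units; beyond the scatter).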

Compound 4, half-maximal inhibitory concentration: 1220 nM
The estimate for compound 4 lay 4.1-fold (0.61 log units) below the measured number; measured number above the stated range.
By their numbers in this assay, from the lowest: compound 3; then compounds 4 and 1 (each within the scatter of the next); then compound 2.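

With 1H-indol-2-yl on the carbonyl carbon, this assay shows a 2.7-fold lower number from compound 2 to compound 4 (0.44 log units; beyond the scatter), yet also an 8.1-fold higher number from compound 3 to compound 4 (0.91 log units; beyond the scatter), so two bicyclic aromatic groups with one hetero atom each are clearly not interchangeable at this position. The step of a 1.1-fold lower number from compound 1 to compound 4 (0.05 log units; within the scatter) puts 1H-indol-2-yl level with the single-ring 4-fluorophenyl group, so the low number of compound 3 does not extend to every bicyclic aromatic group. Nothing available explains the gap between these two groups. The compounds shown leave open whether a pyridin-2-yl or a 1-methyl-1H-indol-2-yl group on this carbonyl carbon would stand nearer to compound 3 or to compound 4.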